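Bromo replaces the carbamate on the fused ring

The compounds below may be only part of what the source reports. "The series", "measured", "known", "first", "only" and "open" are said of these compounds alone.

Measured compounds:
compound 1 `CO[C@@H]1CN(CC2Cc3ccccc3C2)CC[C@H]1n1c(C)nc2cc(C)ccc21` with 47 nM
compound 2 `CO[C@H]1CN(CCCc2cccc(NC(=O)C3CC3)c2)CC[C@@H]1n1c(C)nc2cc(C)ccc21` with 5.2 nM
compound 3 `COC(=O)Nc1ccc2c(c1)C[C@@H](CN1CC[C@@H](n3c(C)nc4cc(C)ccc43)[C@H](OC)C1)C2` with 20 nM

In an assay on isolated protein for binding affinity to melanin-concentrating hormone receptor 1 (Homo sapiens) (a higher number here means a weaker inhibitor, a lower number a stronger inhibitor), compound 3 sits second highest of the three numbers. Compound 1 gives 47 nM and compound 2 gives 5.2 nM, so compound 3 lies between them, closer to compound 1. Within the data shown here, the only one-point step among the measured compounds is a 2.4-fold lower number from compound 1 to compound 3 (0.37 log units; beyond the scatter), a modest gain from adding the carbamate to the fused ring.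

Compound 4 `CO[C@@H]1CN(C[C@H]2Cc3ccc(Br)cc3C2)CC[C@H]1n1c(C)nc2cc(C)ccc21` differs from compound 3 by bromo in place of (methoxycarbonyl)amino on an aromatic carbon. Among the measured compounds shown here, no measured pair shows this change directly; what bears on it is the step from compound 1 to compound 3, which shows that the bare fused ring and the carbamate-bearing ring differ only modestly. A bromo group at this position is therefore expected to land between those two, most likely close to both. Compound 4 is estimated at 30 nM, range 10 nM to 90 nM, an expected step of a 1.5-fold higher number from compound 3 to compound 4 (0.18 log units; within the scatter), within or barely beyond the scatter.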

Compound 4, inhibition constant: 5 nM
Compound 4: middle estimate off by 6.0-fold (0.78 log units), on the high side, and the stated range ends above it.
By their numbers in this assay, from the lowest: compounds 4 and 2 (each within the scatter of the next); then compound 3; then compound 1.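

In this assay this aromatic carbon of the fused ring proves more responsive than the carbamate alone suggested: bromo in place of hydrogen gives a 9.4-fold lower number from compound 1 to compound 4 (0.97 log units; beyond the scatter), a larger step than a 2.4-fold lower number from compound 1 to compound 3 (0.37 log units; beyond the scatter) seen with the carbamate. Replacing the (methoxycarbonyl)amino group with bromo gives a 4.0-fold lower number from compound 3 to compound 4 (0.60 log units; beyond the scatter), so a single heavy atom with no hydrogen-bond donor or acceptor does better here than the five-atom group that carries them. Nothing at hand explains why bromo gives the lower number. The compounds shown leave open whether chloro, iodo or a methyl group on this carbon would match bromo, and how an amine or a carboxylic acid there would compare. They also leave open whether bromo on another aromatic carbon of the fused ring would give a similar number.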